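The source may report more compounds than this note shows. Statements on the series, on what has been measured and on what is new or still open speak of the compounds shown alone.

Compound 2 `CCCCCCOc1ccc2c(Cl)ccnc2c1` gives 2080 nM in a functional assay on NCI-H1650 cells (Homo sapiens) for cytotoxicity, read by MTT assay, with a stated time of 48 h; on this read-out higher numbers stand for weaker inhibition and lower numbers for stronger inhibition. Among the measured compounds shown here, that is the lowest of the two numbers measured so far, but compound 1 `CCCCOc1ccc2c(Cl)ccnc2c1` sits close by with 2570 nM, and the single measured step, a 1.2-fold lower number from compound 1 to compound 2 (0.09 log units; within the scatter), stays within the scatter, so the two cannot be told apart. Compound 3 `Clc1ccnc2cc(OCCCc3ccccc3)ccc12` has not yet been measured. It differs from compound 2 in one place: phenyl in place of propyl on a saturated chain carbon, three bonds along the chain from an oxygen on an aromatic ring. For the measured compounds named here, the only step that bears on this change is the chain lengthening, a 1.2-fold lower number from compound 1 to compound 2 (0.09 log units; within the scatter), and that one did not move the number beyond the scatter. Going by the values given here, a ring entering at the end of the chain is a different kind of change from an alkyl extension, so there is no measured precedent for it. On this basis the step from compound 2 to compound 3 in this assay is expected to be small, a 1.2-fold lower number from compound 2 to compound 3 (0.06 log units; within the scatter), with wide uncertainty. Compound 3 is therefore estimated at 1800 nM, within a range from 600 nM to 5400 nM.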

Compound 3, half-maximal inhibitory concentration: 630 nM
Compound 3: middle estimate off by 2.9-fold (0.46 log units), on the high side, within the range that was stated.
By their numbers in this assay, from the lowest: compound 3; then compounds 2 and 1 (each within the scatter of the next).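

Placing a ring on a saturated chain carbon, three bonds along the chain from an oxygen on an aromatic ring, changes the result in this assay in a way that alkyl lengthening did not: phenyl in place of propyl gives a 3.3-fold lower number from compound 2 to compound 3 (0.52 log units; beyond the scatter), whereas the earlier chain extension gave only a 1.2-fold lower number from compound 1 to compound 2 (0.09 log units; within the scatter). Phenyl in place of methyl gives a 4.1-fold lower number from compound 1 to compound 3 (0.61 log units; beyond the scatter), so among these three compounds, the number moves beyond the scatter only when the phenyl enters. Nothing available here explains why the number falls with this change.

The three compounds leave open whether a longer chain bearing the same phenyl would give a lower or a higher number. They also leave open how an amine or a carboxylic acid in place of the phenyl would read in this assay.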